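The compounds below may be only part of what the source reports. "The series", "measured", "known", "first", "only" and "open" are said of these compounds alone.

Two compounds of this series have so far been run in an assay on membranes from liver for displacement of a labelled ligand from Sigma non-opioid intracellular receptor 1 (Rattus norvegicus), read by scintillation counting; on this read-out higher numbers stand for weaker inhibition and lower numbers for stronger inhibition. Compound 1 `COc1ccc(CN(C)C(C)CCn2c(=O)oc3ccccc32)cc1` gives 21 nM. Compound 2 `CN(CCCCn1c(=O)oc2ccccc21)Cc1cccc(Cl)c1` gives 302 nM, the highest of the two numbers; its nearest neighbour is compound 1, whose number is lower by a margin beyond the usual scatter of repeated measurements.

Compound 3 `CN(CCCCn1c(=O)oc2ccccc21)Cc1ccccc1` has not yet been measured in this assay. It differs from compound 2 by hydrogen in place of chloro on an aromatic carbon. Within the data shown here, no measured pair isolates this change, so the size of its step is not known from the data at hand. For compound 3 the expected step is a 1.5-fold higher number from compound 2 to compound 3 (0.17 log units; within the scatter), small, towards a higher number, and not clearly beyond the scatter. Compound 3 is therefore estimated at 450 nM in this assay, with a range from 150 nM to 1300 nM.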

Compound 3, inhibition constant: 2.6 nM
The estimate for compound 3 lay 170-fold (2.24 log units) above the measured number; measured number below the stated range.
By their numbers in this assay, from the lowest: compound 3; then compound 1; then compound 2.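

Taken alone, the change from chloro to hydrogen on the aromatic carbon meta to a large group gives, in this assay, a 120-fold lower number from compound 2 to compound 3 (2.07 log units; beyond the scatter), the first step in the series that isolates a single position. One chlorine atom at this place therefore separates a weak binder from a strong one within this pair, a difference far beyond the scatter. No data at hand bear on the reason for a step of this size.

Still open, from the compounds shown here alone, is whether this step belongs to chloro specifically or to any group at this place, a question that fluoro, methyl or nitrile on the same carbon would address. Compound 1 differs from compound 3 in more than one place, so it gives no reading on this position.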